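Carbonyl substituent variation and permeability in the series

The source may report more compounds than this note shows. Statements on the series, on what has been measured and on what is new or still open speak of the compounds shown alone.

Compound 1 `CCC(=O)N1CCC(CN(C2Cc3cc(C#N)ccc3N(Cc3cncn3C)C2)S(=O)(=O)c2ccccn2)CC1` gives 0.5 10^-6 cm/s in an ADME assay on Caco-2 cells (Homo sapiens) for permeability, in the apical to basolateral direction; a lower number here means that the compound crosses the layer more slowly, a higher number that the compound crosses the layer faster; among the three compounds measured it holds the second highest number, close to compound 3 and well apart from compound 2. Compound 2 `Cn1cncc1CN1CC(N(CC2CCN(S(C)(=O)=O)CC2)S(=O)(=O)c2ccccn2)Cc2cc(C#N)ccc21` gives 0.1 10^-6 cm/s in this assay, and compound 3 `Cn1cncc1CN1CC(N(CC2CCN(C(=O)NC(C)(C)C)CC2)S(=O)(=O)c2ccccn2)Cc2cc(C#N)ccc21` gives 0.6 10^-6 cm/s. The step of a 5.0-fold lower number from compound 1 to compound 2 (0.70 log units; beyond the scatter) and the step of a 6.0-fold higher number from compound 2 to compound 3 (0.78 log units; beyond the scatter) are the two that go beyond the scatter, whereas the step of a 1.2-fold higher number from compound 1 to compound 3 (0.08 log units; within the scatter) stays within it.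

Compound 4 `Cn1cncc1CN1CC(N(CC2CCN(C(=O)OCc3ccccc3)CC2)S(=O)(=O)c2ccccn2)Cc2cc(C#N)ccc21` has not yet been measured in this assay. It differs from compound 1 in one place: benzyloxy in place of ethyl on a carbonyl carbon. For the measured compounds named here, the closest precedent is a 1.2-fold higher number from compound 1 to compound 3 (0.08 log units; within the scatter), where the carbonyl was retained and only its other substituent was exchanged, without a step beyond the scatter. The larger steps both involve a methylsulfonyl, which compound 4 does not carry. The expected step of a 1.4-fold higher number from compound 1 to compound 4 (0.15 log units; within the scatter) is therefore none beyond the scatter. Compound 4 is estimated at 0.7 10^-6 cm/s, with a range of 0.3 10^-6 cm/s to 1.6 10^-6 cm/s.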

Compound 4, apparent permeability: 1 10^-6 cm/s
The estimate for compound 4 lay 1.4-fold (0.15 log units) below the measured number; the range from low to high includes it.
By their numbers in this assay, from the lowest: compound 2; then compounds 1, 3 and 4 (each within the scatter of the next).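

At the carbonyl carbon, a group as large as benzyloxy, with its six-membered aromatic ring, is accommodated in this assay without a step beyond the scatter: a 2.0-fold higher number from compound 1 to compound 4 (0.30 log units; within the scatter) and a 1.7-fold higher number from compound 3 to compound 4 (0.22 log units; within the scatter). Only the exchange of methylsulfonyl on the ring amine nitrogen goes beyond the scatter, now with benzyloxycarbonyl as well, at a 10-fold higher number from compound 2 to compound 4 (1.00 log units; beyond the scatter), so the separation of compound 2 from the carbonyl compounds holds across three different carbonyl substituents. No measurement available here accounts for any of these steps.

On these data alone, it remains open whether benzyl on the carbonyl carbon would read like benzyloxy, which would show whether the oxygen matters. Also open, as far as these compounds go, is whether a carboxylic acid or a primary amine at the end of a longer chain on this carbonyl would stay with compounds 1, 3 and 4.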